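Notes on the group carried by the carbonyl carbon

The source may report more compounds than this note shows. Statements on the series, on what has been measured and on what is new or still open speak of the compounds shown alone.

Three measured compounds share one core and differ only in the group on the carbonyl carbon. Compound 1 `Cc1nc(S(C)(=O)=O)ccc1Oc1ncnc(OC2CCN(C(=O)O[C@@H](C)C(F)(F)F)CC2)c1F` gives 109 nM in a functional assay on isolated protein for inhibition of Glucose-dependent insulinotropic receptor (Rattus norvegicus), read by HTRF and cAMP accumulation; on this read-out higher numbers stand for an effect only at larger amounts of compound and lower numbers for an effect already at smaller amounts. Compound 2 `Cc1nc(S(C)(=O)=O)ccc1Oc1ncnc(OC2CCN(C(=O)OC3COC3)CC2)c1F` gives 2500 nM in this assay, and compound 3 `Cc1nc(S(C)(=O)=O)ccc1Oc1ncnc(OC2CCN(C(=O)SC(C)C)CC2)c1F` gives 41.3 nM. Compound 3 stands lowest of the three: the step of a 2.6-fold lower number from compound 1 to compound 3 (0.42 log units; beyond the scatter) and the step of a 61-fold lower number from compound 2 to compound 3 (1.78 log units; beyond the scatter) both end at it and both lie beyond the scatter. The remaining step, a 23-fold higher number from compound 1 to compound 2 (1.36 log units; beyond the scatter), shows how much this one position can move the read-out.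

Compound 4 `CCC(F)(F)C(=O)N1CCC(Oc2ncnc(Oc3ccc(S(C)(=O)=O)nc3C)c2F)CC1` differs from compound 3 by 1,1-difluoropropyl in place of isopropylsulfanyl on a carbonyl carbon. Among the compounds with values here, none of the measured steps exchanges a group joined through sulfur for a carbon chain on this carbonyl carbon, so no step bears on the change directly. Within the data shown here, what the three steps do show is that the read-out is sensitive to whatever sits on this carbonyl carbon, and that compound 3 carries the lowest number so far, so a further drop has no precedent here. The expectation is therefore a modest rise in this assay, estimated as a 2.7-fold higher number from compound 3 to compound 4 (0.43 log units; beyond the scatter). For compound 4 the estimated value in this assay is 110 nM, expected to fall between 30 nM and 450 nM.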

Compound 4, half-maximal effective concentration: 69.2 nM
Estimate against measurement, compound 4: 1.6-fold (0.20 log units) above; low and high end bracket the measured number.
By their numbers in this assay, from the lowest: compounds 3, 4 and 1 (each within the scatter of the next, the first and the last beyond it); then compound 2.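

Within the data shown here, with compound 4, the carbonyl carbon bonded to the amide-type nitrogen in a ring carries a group joined through carbon for the first time, and in this assay the steps of a 1.7-fold higher number from compound 3 to compound 4 (0.22 log units; within the scatter) and a 1.6-fold lower number from compound 1 to compound 4 (0.20 log units; within the scatter) show that this exchange leaves the read-out indistinguishable from the isopropylsulfanyl and 1-(trifluoromethyl)ethoxy compounds. The atom joining the group to the carbonyl carbon can therefore be sulfur, oxygen or carbon among these three compounds, while compound 2 stands apart, as the step of a 36-fold lower number from compound 2 to compound 4 (1.56 log units; beyond the scatter) shows, so the (oxetan-3-yl)oxy group goes against any reading that this position accepts every group. Nothing in the data accounts for the separation of compound 2 from the other three.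

Whether the two fluorine atoms of 1,1-difluoropropyl matter stays open, since the compounds shown include no unfluorinated propyl chain on this carbonyl carbon. Also open, on these data alone, is how an amine or a longer carbon chain in this place would read, and whether it would stay with compound 3, compound 4 and compound 1 or move towards compound 2.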